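A few compounds are considered here, and "the series" means these few. Any claim that something is new, unique, unknown or untested is made for them only; others in the source may bear on it.

Compound 1 `CCCCc1ccc2[nH]c(-c3ccc(OC)cc3)c(/C=N/O)c2c1` is the point of departure. Among the measured compounds shown here, in a functional assay on MDA-MB-231 cells (Homo sapiens) for antiproliferative activity, with a stated time of 4 days (a higher number here means a weaker inhibitor, a lower number a stronger inhibitor), compound 1 gives 40 nM, the lowest of the two numbers so far; the only other measured compound, compound 2 `CCCCc1ccc2[nH]c(-c3ccc(C(F)(F)F)cc3)c(/C=N/NC(=O)c3ccc([N+](=O)[O-])cc3)c2c1`, gives 2040 nM in this assay, a much weaker result, though compound 2 differs from compound 1 in two places at once, so its gap cannot be assigned to either change alone.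

The new compound, compound 3 `CCCCc1ccc2[nH]c(-c3ccc(OC)cc3)c(/C=N/NC(=O)c3cccc(O)c3)c2c1`, is built on the core of compound 1 with one change: ((3-hydroxyphenyl)carbonyl)amino in place of hydroxy on a double-bonded nitrogen. Compound 2 carries a similar carbonylamino group on that same nitrogen and sits far above compound 1 in this assay, which is the only hint available for this kind of change, even though its aryl substituent also differs.

On that basis a step towards a weaker inhibitor is expected, of moderate size, beyond the scatter but well short of the whole gap seen for compound 2. The expected step of a 5.0-fold higher number from compound 1 to compound 3 (0.70 log units; beyond the scatter) reflects this. Compound 3 is accordingly estimated at 200 nM in this assay, with a likely range from 50 nM to 800 nM.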

Compound 3, half-maximal inhibitory concentration: 30 nM
The estimate for compound 3 lay 6.7-fold (0.82 log units) above the measured number, outside the stated range (below it).
By their numbers in this assay, from the lowest: compounds 3 and 1 (each within the scatter of the next); then compound 2.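

In this assay, placing ((3-hydroxyphenyl)carbonyl)amino on the double-bonded nitrogen in place of hydroxy gives a 1.3-fold lower number from compound 1 to compound 3 (0.12 log units; within the scatter), so the two compounds cannot be told apart in this assay. Among the compounds shown here, this is the first reading of that change on its own: on the core of compound 1, the position accepts a much larger group that brings a six-membered aromatic ring, with no loss of activity beyond the scatter. Nothing at hand explains why the two groups give such similar numbers.

Compound 3 differs from compound 2 in more than one place, so the compounds shown do not settle which of those differences accounts for the much higher number of compound 2, 2040 nM. They also leave open whether the hydroxy on the new aromatic ring matters to this result, which a comparison of compound 3 with an analogue bearing an amine or a carboxylic acid in its place could begin to test.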